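Amide-aryl variation on a shared enone core

The source may hold more compounds than are shown below. What is called first, only, known or untested is meant among the compounds shown, and "the series" means these compounds.

Measured compounds:
- compound 1, `O=C(Nc1cccc(/C=C/C(=O)c2nc3ccccc3[nH]2)c1)c1ccccc1`: 2440 nM
- compound 2, `O=C(Nc1cccc(/C=C/C(=O)c2nc3ccccc3[nH]2)c1)c1cccc(Br)c1`: 1560 nM
- compound 3, `Cc1ccc(C(=O)Nc2cccc(/C=C/C(=O)c3nc4ccccc4[nH]3)c2)cc1`: 1660 nM

All three share one core and differ only in the aryl group on the amide carbonyl. In a functional assay on HCT-116 cells (Homo sapiens) for antiproliferative activity, read by MTT assay, with a stated time of 48 h (a higher number here means a weaker inhibitor, a lower number a stronger inhibitor), compound 3 gives 1660 nM, the second highest of the three numbers; its nearest neighbour is compound 2 and its furthest is compound 1, and every gap among the three lies within the scatter.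

Compound 4, `COc1cccc(C(=O)Nc2cccc(/C=C/C(=O)c3nc4ccccc4[nH]3)c2)c1`, is not yet measured. It differs from compound 3 by 3-methoxyphenyl in place of 4-methylphenyl on a carbonyl carbon. Within the data shown here, the steps that bear on this change all alter the same aryl group: a 1.6-fold lower number from compound 1 to compound 2 (0.19 log units; within the scatter), a 1.5-fold lower number from compound 1 to compound 3 (0.17 log units; within the scatter), and a 1.1-fold higher number from compound 2 to compound 3 (0.03 log units; within the scatter). None of them moved this assay beyond the scatter, so in this assay the change to compound 4 is expected to give no step beyond the scatter, a 1.1-fold lower number from compound 3 to compound 4 (0.04 log units; within the scatter). For compound 4 the estimate in this assay is 1500 nM, with a range from 700 nM to 3200 nM.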

Compound 4, half-maximal inhibitory concentration: 3680 nM
Compound 4: the middle estimate sits 2.5-fold (0.39 log units) below what was measured; the whole stated range lies below it.
By their numbers in this assay, from the lowest: compounds 2, 3, 1 and 4 (each within the scatter of the next, the first and the last beyond it).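

In this assay, among these compounds, the aryl group on the amide carbonyl now gives steps beyond the scatter, which no earlier pair did: modest ones for 3-methoxyphenyl in place of 4-methylphenyl (a 2.2-fold higher number from compound 3 to compound 4 (0.35 log units; beyond the scatter)) and for methoxy in place of bromo (a 2.4-fold higher number from compound 2 to compound 4 (0.37 log units; beyond the scatter)). Methoxy in place of hydrogen stays within the scatter (a 1.5-fold higher number from compound 1 to compound 4 (0.18 log units; within the scatter)), so the 3-methoxyphenyl group separates from the groups of compound 2 and compound 3 but not from the phenyl group of compound 1. Nothing available bears on the reason for these steps.

The step from compound 3 to compound 4 changes both the substituent and its place on the ring, and a 3-methylphenyl or 4-methoxyphenyl group would be needed to tell these apart. On these data alone, how an amine or a carboxylic acid on this ring would read also remains open.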